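Cytotoxicity of a cyclic carbamate series: a carbamate replaces a benzoate

This account rests on a few compounds, and the source may have more. Where it says the series, first, only, none or still open, it means among the compounds named here.

Of the compounds shown here, three sharing one core have been measured in an ADME assay on HEK293-A cells (Homo sapiens) for cytotoxicity, read by MTT assay, with a stated time of 48 h; a lower number here means a stronger inhibitor, a higher number a weaker inhibitor. For the measured compounds named here, compound 1 `O=C1O[C@@H](CN2CCC(c3ccc(F)cc3)CC2)CN1c1ccc(-n2cc(-c3ccccn3)cn2)c(F)c1` is the first of them. In this assay compound 1 gives > 400 ug/mL, which is a limit of the assay rather than a number. Compound 2 `O=C1CCC(=O)N1C[C@H]1CN(c2ccc(-n3cc(-c4ccccn4)cn3)c(F)c2)C(=O)O1` carries a 2,5-dioxopyrrolidin-1-yl group on the saturated chain carbon. In this assay compound 2 gives > 400 ug/mL, again a limit. Compound 3 `O=C(OC[C@H]1CN(c2ccc(-n3cc(-c4ccccn4)cn3)c(F)c2)C(=O)O1)c1ccccc1` carries benzoyloxy at the same position. In this assay compound 3 gives > 400 ug/mL, also a limit. Going by the values given here, the only one-place step among the measured compounds, a step that the two limits leave unreadable from compound 2 to compound 3, cannot be read in size, because both ends sit at the limit described in the limit of > 400 ug/mL in this assay, at which 3 of the 3 values shown sit.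

Compound 4 `COC(=O)NC[C@H]1CN(c2ccc(-n3cc(-c4ccccn4)cn3)c(F)c2)C(=O)O1` is the next compound to be measured. It differs from compound 3 in one place: (methoxycarbonyl)amino in place of benzoyloxy on a saturated chain carbon bound to a saturated ring carbon. Among the compounds with values here, no measured step bears on this change, and the three values so far all rest at the same limit. Compound 4 is therefore expected to remain at or near that limit in this assay, with an estimated step of a number no higher from compound 3 to compound 4 (the limit leaves the size open). The estimate for compound 4 is 400 ug/mL, within a range from 200 ug/mL to 800 ug/mL.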

Compound 4, half-maximal inhibitory concentration: 306 ug/mL
Beside the measured number, compound 4's estimate is 1.3-fold (0.12 log units) above it, within the range that was stated.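

In this assay, for the compounds shown here, compound 4 is the first of the series to give a measured number rather than a limit, so this position on a saturated chain carbon bound to a saturated ring carbon now has one readable end: the limit of > 400 ug/mL in this assay, at which 3 of the 4 values shown sit. Placing (methoxycarbonyl)amino where benzoyloxy stood gives an at least 1.3-fold lower number from compound 3 to compound 4 (0.11 log units; that floor lies within the scatter), and placing the same group where 2,5-dioxopyrrolidin-1-yl stood gives an at least 1.3-fold lower number from compound 2 to compound 4 (0.11 log units; that floor lies within the scatter). Going by these compounds, both steps are floors, so their true size stays open, and the floors themselves do not go beyond the usual scatter of repeated measurements.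

The compounds shown leave open how the number would move with an amine, a carboxylic acid or a longer chain in place of (methoxycarbonyl)amino at this position. They also cannot separate the hydrogen-bond donor that enters with (methoxycarbonyl)amino from the loss of the aromatic ring of benzoyloxy, as the two travel together in this single change.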